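The source may report more compounds than this note shows. Statements on the series, on what has been measured and on what is new or still open speak of the compounds shown alone.

Measured so far:
- compound 1 `CCOc1ccc(NC(=O)c2c(N)n[nH]c2Nc2ccccc2)cc1`, which in an ADME assay on TERT-RPE1 cells (Homo sapiens) for cytotoxicity, read by resazurin assay, with a stated time of 48 h (a lower number here means a stronger inhibitor, a higher number a weaker inhibitor), gives 67800 nM
- compound 2 `CCNc1[nH]nc2nnn(-c3ccc(OCC)cc3)c(=O)c12`, for which this assay reports only a limit, > 100000 nM

For the measured compounds named here, compound 1 stands as the only plain number in this set; the other value, that of compound 2, is a limit rather than a measurement (the limit of > 100000 nM in this assay, at which 1 of the 2 values shown sits). Compound 3 `CCOc1ccc(NC(=O)c2c(N)n[nH]c2NC)cc1` differs from compound 1 in one place, as a single change to the nitrogen on the aromatic ring: methyl in place of phenyl on a nitrogen on an aromatic ring. Going by the values given here, no measured pair of compounds differing in one place is available, so the size of such a step has not yet been seen here. The step of a 1.3-fold higher number from compound 1 to compound 3 (0.12 log units; within the scatter) is expected to be small, either none beyond the scatter or a slight move toward a weaker value, with a real chance that the assay again reports only a limit. Compound 3 is therefore estimated at 90000 nM, in a range from 30000 nM to 300000 nM.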

Compound 3, half-maximal inhibitory concentration: > 100000 nM
Compound 3: no number, only a limit; the forecaster's own chance of this, stated with the estimate: 55%; at least 1.1-fold (0.04 log units) between middle value and limit.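

In this assay compound 3 reaches only a limit of the assay, > 100000 nM, so it has no exact value. Going from anilino to methylamino on this nitrogen gives the first step measured between compounds that differ in one place, an at least 1.4-fold higher number from compound 1 to compound 3 (0.16 log units; that floor lies within the scatter), and since that floor lies within the scatter, this result alone does not establish a real change, while the true step could be larger. Compound 3 also joins compound 2 at the top of the measurable range: the limit of > 100000 nM in this assay, at which 2 of the 3 values shown sit.

On these data alone, the actual size of the step therefore remains open. So does whether an intermediate group on this nitrogen, such as a longer chain like propyl or a benzyl, would give a plain number or another limit.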